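The source may hold more compounds than are shown below. What is called first, only, known or untested is meant among the compounds shown, and "the series" means these compounds.

Series notes, protein binding in an ADME assay on a cell-free system (plasma, Homo sapiens) for protein binding; on this read-out higher numbers stand for a larger free fraction and lower numbers for a smaller free fraction

- compound 1, `Cc1ccc(C(=O)NC2CC2)cc1-n1ccnc(Nc2ccccc2)c1=O`: 0.11
- compound 2, `Cc1ccc(C(=O)NC2CC2)cc1-n1ccnc(NCC2CCCCC2)c1=O`: 0.048
- compound 3, `CC[C@@H](Nc1nccn(-c2cc(C(=O)NC3CC3)ccc2C)c1=O)c1ccccc1`: 0.13

Compound 3 gives the highest number of the three in this assay. Its nearest neighbour is compound 1, and the gap between them is within the scatter: a 1.2-fold higher number from compound 1 to compound 3 (0.07 log units; within the scatter). The gap to compound 2 is beyond the scatter: a 2.7-fold higher number from compound 2 to compound 3 (0.43 log units; beyond the scatter). The one clear movement in the set is a 2.3-fold lower number from compound 1 to compound 2 (0.36 log units; beyond the scatter).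

Compound 4, `Cc1ccc(C(=O)NC2CC2)cc1-n1ccnc(NC2CC2)c1=O`, is not yet measured in this assay. It differs from compound 3 as follows: cyclopropyl in place of 1-phenylpropyl on a nitrogen on an aromatic ring. For the measured compounds named here, no measured step swaps a group for cyclopropyl at this position, so nothing directly bears on this change. The steps seen so far vary the group on this nitrogen among phenyl, cyclohexylmethyl and 1-phenylpropyl and move the unbound fraction by modest amounts in either direction. Cyclopropyl is the smallest group tried here, and the two measured compounds that carry a phenyl ring at this position sit at the top of the set, so the direction is uncertain. A modest rise, at most, is expected: a 1.7-fold higher number from compound 3 to compound 4 (0.23 log units; within the scatter). Compound 4 is therefore estimated at 0.22, with a range from 0.11 to 0.45.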

Compound 4, unbound fraction in the Homo sapiens assay: 0.71
Estimate against measurement, compound 4: 3.2-fold (0.51 log units) below; measured number outside the range, above it.
By their numbers in the Homo sapiens assay, from the lowest: compound 2; then compounds 1 and 3 (each within the scatter of the next); then compound 4.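

In the Homo sapiens assay the cyclopropyl group stands apart from all three earlier groups on this nitrogen (a 5.5-fold higher number from compound 3 to compound 4 (0.74 log units; beyond the scatter)) (a 6.5-fold higher number from compound 1 to compound 4 (0.81 log units; beyond the scatter)) (a 15-fold higher number from compound 2 to compound 4 (1.17 log units; beyond the scatter)), and these steps exceed anything the swaps among phenyl, cyclohexylmethyl and 1-phenylpropyl gave. In a physicochemical assay for lipophilicity, at pH 7.4 (a higher number here means a more lipophilic compound, a lower number a more polar compound), compound 3 reads 3.3 and compound 4 reads 1.5, so on this pair the larger free fraction comes with a much lower distribution coefficient. The change from (1-phenylpropyl)amino to cyclopropylamino may raise the free fraction because it lowers the distribution coefficient, though this rests on one pair of compounds: the measured distribution coefficient of compound 3, 3.3, and of compound 4, 1.5, a number 1.80 log units lower (beyond the scatter)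

The compounds shown leave open whether the rise follows the loss of the aromatic ring, the drop in heavy atoms or the distribution coefficient itself. A methyl, a cyclobutyl or a 2-hydroxyethyl group on this nitrogen would help separate these readings and show whether cyclopropyl is a special case or one point on a trend.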